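A few compounds are considered here, and "the series" means these few. Any claim that something is new, unique, unknown or untested is made for them only; others in the source may bear on it.

The measured compounds:
compound 1, `O=C(CN(c1nc(Cl)nc2[nH]cnc12)C1CC1)NCC(=O)OCc1ccccc1`, with 27.2% in a functional assay on the whole organism (Tail, strain ICR) with Mus musculus as the target, in the tail flick test, with a stated time of 90 min, at a dose of 25 umol/kg by the oral route; a higher number here means a stronger effect of the compound at the dose given, a lower number a weaker effect
compound 2, `CC[C@H](C)[C@H](NC(=O)CN(c1nc(Cl)nc2[nH]cnc12)C1CC1)C(=O)OCc1ccccc1`, with 36.3% in this assay

Compound 2 holds the higher of the two numbers in this assay, but the step of a number 9.1 percentage points higher from compound 1 to compound 2 (within the scatter) is within the scatter, so the two compounds cannot be told apart on this evidence. Compound 3, `NC(=O)CC[C@H](NC(=O)CN(c1nc(Cl)nc2[nH]cnc12)C1CC1)C(=O)OCc1ccccc1`, has not been measured; it differs from compound 2 in one place: 2-carbamoylethyl in place of sec-butyl on a saturated chain carbon bound to an amide-type nitrogen and a carbonyl carbon. Among the compounds with values here, the only measured step touches the same place, where hydrogen was exchanged for sec-butyl, and it stayed within the scatter. Nothing measured shows what a 2-carbamoylethyl group does at this place. The expectation for compound 3 is therefore no step beyond the scatter, with the step of a number 3.3 percentage points lower from compound 2 to compound 3 (within the scatter) expected to be small. In this assay compound 3 is estimated to give 33%, between 15% and 55%.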

Compound 3, a percentage reported as activity, at one dose (the size of the read-out at that dose, not a potency): 42.8%
Estimate against measurement, compound 3: 9.8 percentage points below, within the range that was stated.
By their numbers in this assay, from the lowest: compounds 1, 2 and 3 (each within the scatter of the next, the first and the last beyond it).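

In this assay, within the data shown here, 2-carbamoylethyl in place of hydrogen on this saturated chain carbon gives a number 15.6 percentage points higher from compound 1 to compound 3 (beyond the scatter) and is the first step at this place to pass the scatter. Set against sec-butyl, the same group gives a number 6.5 percentage points higher from compound 2 to compound 3 (within the scatter) so these two side chains cannot be told apart here, although 2-carbamoylethyl carries a hydrogen-bond donor and acceptor and sec-butyl carries neither. No supporting data bear on why the step from hydrogen arises.

As far as these compounds go, it remains open whether this step is particular to 2-carbamoylethyl or whether another chain at this carbon, such as one ending in a carboxylic acid or an amine, would give a larger or smaller number. These readings also come from one dose, so they show the size of the effect there and not a potency.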